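This account rests on a few compounds, and the source may have more. Where it says the series, first, only, none or still open, it means among the compounds named here.

Compound 1 `CC(=O)Nc1cccc(-c2ccc(C(=O)N(Cc3cccc(OCCCCCC(=O)O)c3)C(C)C)cc2)c1` gives > 26000 nM in an ADME assay on HEK293 cells (Homo sapiens) for cytotoxicity, read by CellTiter-Glo and resazurin assay, with a stated time of 72 h (on this read-out lower numbers stand for an effect already at smaller amounts and higher numbers for an effect only at larger amounts of compound), which is a limit of the assay rather than a number.
Compound 2 `CCOC(=O)CCCCCOc1cccc(CN(C(=O)c2ccc(-c3ccc4ccccc4c3)cc2)C(C)C)c1` gives > 26000 nM in this assay, again a limit rather than a number.

Compound 2 therefore stands exactly where compound 1 stands: both results are limits, and both sit at the limit of > 26000 nM in this assay, at which 2 of the 2 values shown sit. For the measured compounds named here, no step between measured compounds is available here, so nothing shows how a change at this position moves the read-out in this assay.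

Compound 3 `CCOC(=O)CCCCCOc1cccc(CN(C(=O)c2ccc(-c3cccc(-c4nnc(C)o4)c3)cc2)C(C)C)c1` differs from compound 2 by 3-(5-methyl-1,3,4-oxadiazol-2-yl)phenyl in place of naphthalen-2-yl on an aromatic carbon. The step that the limit leaves unreadable from compound 2 to compound 3 is expected to be none beyond the scatter, since both measured compounds sit at the limit of > 26000 nM in this assay, at which 2 of the 2 values shown sit, and the change touches only the group at the far end of the core. Compound 3 is estimated at 30000 nM, within 10000 nM to 100000 nM, and most likely it too will be reported only as a limit.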

Compound 3, half-maximal effective concentration: > 26000 nM
Compound 3 was reported as a limit; the forecaster's own chance of this, stated with the estimate: 85%; the middle value does not contradict the limit.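

Compound 2 and compound 3 both stand as limits of the assay rather than numbers, so no step between them can be read: the limit of > 26000 nM in this assay, at which 3 of the 3 values shown sit.

The compounds shown leave open how far any of them lies beyond that limit, and whether any change on the shared core gives a readable value.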